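The source may hold more compounds than are shown below. What is called first, only, known or untested is meant among the compounds shown, and "the series" means these compounds.

Among the compounds with values here, in a functional assay on A-431 cells (Homo sapiens) for cytotoxicity, read by MTT assay, with a stated time of 24 h (on this read-out higher numbers stand for weaker inhibition and lower numbers for stronger inhibition), compound 1 `O=C(COC(=O)/C=C/c1ccccc1)NCCC[Te]c1ccccc1` gives 6000 nM, the only plain number among the three measured compounds. Compound 2 `COc1ccc(N(CC(=O)NCCCSc2ccccc2)C(=O)/C=C/c2ccccc2)cc1` reaches only a limit of this assay, >= 100000 nM. Compound 3 `COc1ccc(N(CC(=O)NCCCSc2ccccc2)C(=O)C#Cc2ccccc2)cc1` likewise stops at a limit, >= 100000 nM. How the core of compound 1 differs from the core of compound 2 is not broken down here.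

Compounds 2 and 3 differ by one change, (2-phenylethynyl in place of 2-phenylethenyl on a carbonyl carbon), and the step between them in this assay is a step that the two limits leave unreadable from compound 2 to compound 3: it cannot be read, since both values sit at the limit of >= 100000 nM in this assay, at which 2 of the 3 values shown sit.

Compound 4 `O=C(COC(=O)C#Cc1ccccc1)NCCC[Te]c1ccccc1` is not yet measured. It differs from compound 1 by 2-phenylethynyl in place of 2-phenylethenyl on a carbonyl carbon. This is the same kind of change as that from compound 2 to compound 3, but not the same: in compound 2 the carbonyl carbon's other neighbour is an amide-type nitrogen, whereas in compound 1 it is an oxygen next to a carbonyl group. Within the data shown here, the only measured example of this change gives no readable size, so the expectation for compound 4 rests on compound 1 alone, which gives 6000 nM in this assay. Compound 4 is expected to give about 7000 nM in this assay, somewhere between 2000 nM and 40000 nM. The estimated step is a 1.2-fold higher number from compound 1 to compound 4 (0.07 log units; within the scatter), expected to stay small because the starting value of compound 1 is 6000 nM and no readable step argues for a larger move.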

Compound 4, half-maximal inhibitory concentration: 7000 nM
Beside the measured number, compound 4's estimate shows no gap at the digits printed, within the range that was stated.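

In this assay, putting 2-phenylethynyl in place of 2-phenylethenyl on a carbonyl carbon whose other neighbour is an oxygen next to a carbonyl group gives a 1.2-fold higher number from compound 1 to compound 4 (0.07 log units; within the scatter), so on the core of compound 1 this pair does not separate the two groups. On the core of compound 2 the same exchange cannot be read, since compound 2 and compound 3 each give a limit of the assay and not a number: the limit of >= 100000 nM in this assay, at which 2 of the 4 values shown sit. The change therefore has one readable case, which does not show whether the result on the core of compound 1 carries over to the core of compound 2, or to any other core in the series.

The compounds shown leave open how a saturated 2-phenylethyl group, or a phenyl ring carrying an amine or a carboxylic acid, would read at the same carbonyl carbon in this assay. They also leave open how the core of compound 1 would read with sulfur in place of tellurium, a single change that would give a direct comparison for the tellurium atom.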